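Acid to ethylamide at the carbonyl of compound 1

The source may hold more compounds than are shown below. What is called first, only, known or untested is meant among the compounds shown, and "the series" means these compounds.

Measured compounds:
Compound 1 `COc1ccc(Nc2ncnc3c2ncn3C2O[C@H](C(=O)O)[C@@H](O)[C@H]2O)cc1` gives 2 nM in a functional assay on the whole organism with Canis familiaris (Canis lupus familiaris) as the target; a higher number here means that more compound is needed for the effect, a lower number that less compound is needed.
Compound 2 `CCC(CC)Nc1ncnc2c1ncn2C1O[C@H](C(=O)NC2CC2)[C@@H](O)[C@H]1O` gives 1.9 nM in this assay.
Compound 3 `CNc1ncnc2c1ncn2C1O[C@H](C(=O)O)[C@@H](O)[C@H]1O` gives 0.46 nM in this assay.

Compound 1 stands at the highest of the three numbers in this assay. Compound 2 sits nearest to it, within the usual scatter, and compound 3 sits furthest, with a 4.3-fold lower number from compound 1 to compound 3 (0.64 log units; beyond the scatter).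

Compound 4 `CCNC(=O)[C@H]1OC(n2cnc3c(Nc4ccc(OC)cc4)ncnc32)[C@H](O)[C@@H]1O` has not been measured. It differs from compound 1 in one place: ethylamino in place of hydroxy on a carbonyl carbon. Within the data shown here, the one measured step, a 4.3-fold lower number from compound 1 to compound 3 (0.64 log units; beyond the scatter), concerns the substituent on the aromatic ring nitrogen, not the carbonyl carbon, so it does not bear on this change. Compound 2 carries an amide at the carbonyl carbon rather than an acid, but it also differs at the ring nitrogen, so only its value can be set beside that of compound 1. Compound 2 gives 1.9 nM, and compound 1 gives 2 nM; the two lie within the scatter. No step beyond the scatter is therefore expected from the change to an amide. Compound 4 is expected to show no change at the digits printed from compound 1 to compound 4 (within the scatter). For compound 4 the estimate is 2 nM, with a range from 0.7 nM to 6 nM.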

Compound 4, half-maximal effective concentration: 3.5 nM
Beside the measured number, compound 4's estimate is 1.8-fold (0.24 log units) below it; the measured number falls inside the stated range.
By their numbers in this assay, from the lowest: compound 3; then compounds 2, 1 and 4 (each within the scatter of the next).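

In this assay, among these compounds, the change from carboxy to ethylcarbamoyl gives the first direct reading at the carbonyl carbon: the step of a 1.8-fold higher number from compound 1 to compound 4 (0.24 log units; within the scatter) stays within the scatter, so the two compounds cannot be told apart. With the 4-methoxyphenyl group on the ring nitrogen held constant, the carboxy group is therefore not needed for a number of this size, at least in this single pair. Nothing at hand bears on the origin of this result.

On these data alone, whether the same change holds with methyl on the ring nitrogen remains open, as the step of a 4.3-fold lower number from compound 1 to compound 3 (0.64 log units; beyond the scatter) was read only with the carboxy group in place. Also open, as far as these compounds go, is how other groups on the carbonyl carbon, such as amino or propylamino, would read in this assay.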